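The compounds below may be only part of what the source reports. "The series", "measured", "known", "first", "only" and "open" are said of these compounds alone.

Compound 1 `CC(C)c1cc(C(C)(C)C)cc(-c2ccc(F)cc2)c1CO` is the starting point here. In a functional assay on RKE cells for antagonist activity at Vasoactive intestinal polypeptide receptor 1 (Rattus norvegicus), read by HTRF and cAMP accumulation, with stated times of 10 min and 30 min (on this read-out lower numbers stand for stronger inhibition and higher numbers for weaker inhibition), compound 1 gives 740 nM. Within the data shown here, the only other measured compound, compound 2 `CCC(=O)Nc1sc2c(c1C#N)CCCC2`, gives 12000 nM in this assay, so compound 1 holds the lower of the two numbers, and the gap between them lies well beyond the usual scatter of repeated measurements. Compound 2 shares no obvious framework with compound 1, so its value says little about small changes to compound 1.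

The next compound, compound 3 `Cc1ccccc1-c1cc(C(C)(C)C)cc(C(C)C)c1CO`, keeps the core of compound 1 and differs only in one place: 2-methylphenyl in place of 4-fluorophenyl on an aromatic carbon. Among the measured compounds shown here, no measured pair in this set shows what such a swap of one aromatic substituent for another does, so the expectation rests on compound 1 alone. The expected step of a 1.2-fold higher number from compound 1 to compound 3 (0.09 log units; within the scatter) is judged small, close to the scatter. For compound 3 the estimated value in this assay is 900 nM, within a range from 300 nM to 3000 nM.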

Compound 3, half-maximal inhibitory concentration: > 50000 nM
Compound 3 ended at the assay's limit; the forecaster's own chance of this, stated with the estimate: 5%; at least 55-fold (1.74 log units) between middle value and limit.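

Compound 1 and compound 3 show that this position is far from indifferent to the choice of aromatic group. The two groups have the same heavy-atom count, one six-membered aromatic ring each and no hydrogen-bond donors or acceptors, yet in this assay swapping 4-fluorophenyl for 2-methylphenyl gives an at least 67-fold higher number from compound 1 to compound 3 (1.82 log units; beyond the scatter). That step is only a lower bound, because compound 3 sits at a limit of the assay and not at a measured number: the limit of > 50000 nM in this assay, at which 1 of the 3 values shown sits.

Still open, on these data alone, is whether the step goes with gaining the methyl group, losing the fluorine or changing where the substituent sits on the ring, a question that 4-methylphenyl or 2-fluorophenyl could help to settle. Also open, as far as these compounds go, is how an unsubstituted phenyl or an aminophenyl group would behave at this position.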